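This account rests on a few compounds, and the source may have more. Where it says the series, first, only, none or still open, it means among the compounds named here.

The shared core of compound 1 `O=C(CN1CCCC1)N1CCC(NS(=O)(=O)c2cc(S(=O)(=O)c3ccccc3)ccc2C(F)(F)F)CC1` carries, on a carbonyl carbon bound to a ring nitrogen, a small saturated group. In a functional assay on U2OS cells for antagonist activity at proto-oncogene Wnt-3 (Homo sapiens), read by a luciferase reporter, with a stated time of 18 h (on this read-out higher numbers stand for an effect only at larger amounts of compound and lower numbers for an effect already at smaller amounts), compound 1 gives 190 nM. Among the measured compounds shown here, two companions vary only that group. Compound 2 `O=C(CN1CCNCC1)N1CCC(NS(=O)(=O)c2cc(S(=O)(=O)c3ccccc3)ccc2C(F)(F)F)CC1` gives 250 nM in this assay, and compound 3 `O=C1CC[C@@H](C(=O)N2CCC(NS(=O)(=O)c3cc(S(=O)(=O)c4ccccc4)ccc3C(F)(F)F)CC2)N1` gives 240 nM. Compound 1 sits at one end of these three numbers, with compound 3 nearest and compound 2 furthest, yet both gaps are within the scatter: a 1.3-fold higher number from compound 1 to compound 2 (0.12 log units; within the scatter) and a 1.3-fold higher number from compound 1 to compound 3 (0.10 log units; within the scatter). The two measured changes at this position therefore left the read-out essentially unchanged.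

Compound 4 `CC(C)(C)CC(=O)N1CCC[C@H]1C(=O)N1CCC(NS(=O)(=O)c2cc(S(=O)(=O)c3ccccc3)ccc2C(F)(F)F)CC1` has not yet been measured. It differs from compound 1 at the same position: 1-(neopentylcarbonyl)pyrrolidin-2-yl in place of (pyrrolidin-1-yl)methyl on a carbonyl carbon. The entering group is larger than anything tried so far here, so the measured steps are only a partial guide. Because a 1.3-fold higher number from compound 1 to compound 2 (0.12 log units; within the scatter) and a 1.3-fold higher number from compound 1 to compound 3 (0.10 log units; within the scatter) were both within the scatter, the expectation is that this position tolerates change and that compound 4 will show a step no larger than the scatter in this assay, in either direction. The estimated step from compound 1 is a 1.3-fold higher number from compound 1 to compound 4 (0.12 log units; within the scatter). Compound 4 is expected to give about 250 nM, most likely between 100 nM and 650 nM.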

Compound 4, half-maximal effective concentration: 120 nM
Compound 4: the middle estimate sits 2.1-fold (0.32 log units) above what was measured, and the stated range covers the measured number.
By their numbers in this assay, from the lowest: compounds 4, 1, 3 and 2 (each within the scatter of the next, the first and the last beyond it).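

In this assay, the position on a carbonyl carbon bound to an amide-type nitrogen in a ring accepts a much larger group: 1-(neopentylcarbonyl)pyrrolidin-2-yl has 12 heavy atoms against 6 in the (pyrrolidin-1-yl)methyl it replaces, and the result is still within the scatter (a 1.6-fold lower number from compound 1 to compound 4 (0.20 log units; within the scatter)). Set against the other two groups, the same entering group gives one more step within the scatter (a 2.0-fold lower number from compound 3 to compound 4 (0.30 log units; within the scatter)) and the first step at this position that lies beyond it, though only modestly (a 2.1-fold lower number from compound 2 to compound 4 (0.32 log units; beyond the scatter)). No measurement is available that would explain these steps.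

From the compounds shown here alone, whether a plain pyrrolidin-2-yl with a free ring amine, or an acetyl in place of the neopentylcarbonyl on that ring nitrogen, would give a similar number remains open, so the part played by the neopentylcarbonyl piece is unknown. Also open, going by these compounds, is how a carboxylic acid or a longer carbon chain would read at this carbonyl carbon, and whether the opposite configuration at the defined stereocentre would change the number.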